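The source may report more compounds than this note shows. Statements on the series, on what has been measured and on what is new or still open speak of the compounds shown alone.

Series on the shared core of compound 1 `Cc1ccc(NC(=O)c2c(NO)cc(-c3ccc(C)cc3)oc2=O)cc1`, read in an ADME assay on Huh-7 cells (Homo sapiens) for cytotoxicity, read by a luciferase reporter and WST assay, with a stated time of 3 days; on this read-out higher numbers stand for lower toxicity in this test and lower numbers for higher toxicity in this test. In this assay compound 1 gives > 20000 nM, which is a limit of the assay and not a number. Compound 2 `COc1ccc(-c2cc(NO)c(C(=O)Nc3ccc(C)cc3)c(=O)o2)cc1` differs from compound 1 by methoxy in place of methyl on an aromatic carbon. In this assay compound 2 gives > 20000 nM, again a limit. The two limits leave a step that the two limits leave unreadable from compound 1 to compound 2 without a readable size. Compound 3 `Cc1ccc(-c2cc(NO)c(C(=O)NCCO)c(=O)o2)cc1` carries a different core, the difference being (2-hydroxyethyl in place of 4-methylphenyl on an amide-type nitrogen). In this assay compound 3 gives > 20000 nM, also a limit. Likewise a step that the two limits leave unreadable from compound 1 to compound 3 cannot be sized. The three values share (the limit of > 20000 nM in this assay, at which 3 of the 3 values shown sit). Compound 4 `COc1ccc(-c2cc(NO)c(C(=O)NCCO)c(=O)o2)cc1` stands to compound 3 as compound 2 stands to compound 1, the same change: methoxy in place of methyl on an aromatic carbon. The expected step is a step that the limit leaves unreadable from compound 3 to compound 4, resting on the unreadable a step that the two limits leave unreadable from compound 1 to compound 2. Compound 4 is expected to remain at the limit, estimated at 30000 nM.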

Compound 4, half-maximal cytotoxic concentration: > 20000 nM
Compound 4: no number, only a limit (the forecaster's own chance of this, stated with the estimate: 90%); the middle value lies beyond the limit too.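

No step can be read from compound 3 to compound 4 or from compound 2 to compound 4, because each value is a limit of the assay and not a number: the limit of > 20000 nM in this assay, at which 4 of the 4 values shown sit.

The compounds shown leave open whether methoxy in place of methyl, or 2-hydroxyethyl in place of 4-methylphenyl, changes the half-maximal cytotoxic concentration at all.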